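From an Ethynyl Ester to a Hydroxyphenyl Triazole

The compounds below may be only part of what the source reports. "The series", "measured", "known", "first", "only" and "open" are said of these compounds alone.

In a functional assay on PC-3 cells (Homo sapiens) for antiproliferative activity, read by MTT assay, with a stated time of 48 h (on this read-out lower numbers stand for stronger inhibition and higher numbers for weaker inhibition), compound 2 `C#CCOC(=O)/C(C)=C/CC/C(C)=C/CC/C(C)=C/CC[C@@H]1[C@@]2(C)CCC(=O)C(C)(C)[C@H]2CC[C@@]1(C)O` gives 18900 nM, level with compound 3 `C/C(=C\CC/C(C)=C/CC[C@@H]1[C@@]2(C)CCC(=O)C(C)(C)[C@H]2CC[C@@]1(C)O)CC/C=C(\C)C(=O)OCc1cn([C@@H]2C[C@@H](n3cc(C)c(=O)[nH]c3=O)O[C@H]2CO)nn1` at 18900 nM. Compound 1 `C/C(=C\CC/C(C)=C/CC[C@@H]1[C@@]2(C)CCC(=O)C(C)(C)[C@H]2CC[C@@]1(C)O)CC/C=C(\C)C(=O)OCc1cn(-c2ccc(F)c(Cl)c2)nn1` gives 22900 nM, within the usual scatter of both. Compound 4 `C/C(=C\CC/C(C)=C/CC[C@@H]1[C@@]2(C)CCC(=O)C(C)(C)[C@H]2CC[C@@]1(C)O)CC/C=C(\C)C(=O)OCc1cn(-c2cccc(O)c2)nn1` differs from compound 2 as follows: 1-(3-hydroxyphenyl)-1H-1,2,3-triazol-4-yl in place of ethynyl on a saturated chain carbon bound to an oxygen next to a carbonyl group. This places 1-(3-hydroxyphenyl)-1H-1,2,3-triazol-4-yl in place of ethynyl on a saturated chain carbon bound to an oxygen next to a carbonyl group. For the measured compounds named here, no measured step isolates this change. Compound 1, which also carries a triazole, stands at 22900 nM, so no step beyond the scatter is expected in this assay. The estimated step is a 1.1-fold higher number from compound 2 to compound 4 (0.02 log units; within the scatter). Compound 4 is expected at 20000 nM, within an estimated range of 10000 nM to 40000 nM.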

Compound 4, half-maximal inhibitory concentration: 6570 nM
For compound 4 the middle estimate is 3.0-fold (0.48 log units) above the measured one, outside the stated range (below it).
By their numbers in this assay, from the lowest: compound 4; then compounds 2, 3 and 1 (each within the scatter of the next).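

In this assay, for the compounds shown here, 1-(3-hydroxyphenyl)-1H-1,2,3-triazol-4-yl in place of ethynyl gives a 2.9-fold lower number from compound 2 to compound 4 (0.46 log units; beyond the scatter) on this read-out, the first step beyond the scatter at this place on the ester. With the triazole kept, the group on it also counts: 3-hydroxyphenyl in place of 3-chloro-4-fluorophenyl on an aromatic nitrogen gives a 3.5-fold lower number from compound 1 to compound 4 (0.54 log units; beyond the scatter) in the same assay. Nothing available here accounts for either step.

The compounds shown leave open how a plain phenyl, a 3-methoxyphenyl or a 3-aminophenyl on the triazole would stand.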